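A few compounds are considered here, and "the series" means these few. Any claim that something is new, unique, unknown or untested is made for them only; others in the source may bear on it.

Measured so far in an ADME assay on HeLa cells (Homo sapiens) for cytotoxicity; a lower number here means that less compound is tolerated, a higher number that more compound is tolerated:
- compound 1 `CCN(CC)CN1C(=O)/C(=N/NC(=S)Nc2ccccc2)c2cc(Cl)ccc21` gives 13500 nM
- compound 2 `CCN(CC)CN1C(=O)/C(=N/NC(=S)Nc2ccc(C)cc2)c2ccccc21` gives 10700 nM
- compound 3 `CCN(CC)CN1C(=O)/C(=N/NC(=S)Nc2ccc(OC)cc2)c2cc(Cl)ccc21` gives 13200 nM

Compound 3 lies within the scatter of both compound 1 and compound 2, so these numbers give it no meaningful rank among the three. The next step leads to compound 4 `CCN(CC)CN1C(=O)/C(=N/NC(=S)Nc2ccc(C)cc2)c2cc(Cl)ccc21` and puts methyl in place of methoxy on an aromatic carbon, para to a large group methyl in place of methoxy on an aromatic carbon in an otherwise unchanged structure.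

Among the compounds with values here, the one measured step at this place is a 1.0-fold lower number from compound 1 to compound 3 (0.01 log units; within the scatter) for methoxy in place of hydrogen, and it stays within the scatter. The 4-methylphenyl group of compound 4 is already present in compound 2, and compound 2 gives 10700 nM on a core without the chlorine. That value also sits close to the other two. Within the data shown here, no measured pair compares methyl with methoxy directly on the chlorinated core, so the expectation rests on these two indirect observations. No step beyond the scatter is expected in this assay here. The estimated change is a 1.1-fold lower number from compound 3 to compound 4 (0.02 log units; within the scatter) and remains a small one. The expected value for compound 4 is 12500 nM, with an estimated range from 7500 nM to 20000 nM.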

Compound 4, half-maximal cytotoxic concentration: > 100000 nM
Compound 4: no number, only a limit; the forecaster's own chance of this, stated with the estimate: 2%; middle value at least 8.0-fold (0.90 log units) from the limit.
By their numbers in this assay, from the lowest: compounds 2, 3 and 1 (each within the scatter of the next). At a limit, above all of these: compound 4.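

In this assay compound 4 gives a limit and not a number: the limit of > 100000 nM in this assay, at which 1 of the 4 values shown sits.

Among the earlier compounds, the only step at this place stayed within the scatter, a 1.0-fold lower number from compound 1 to compound 3 (0.01 log units; within the scatter) for methoxy in place of hydrogen, whereas methyl on the same core gives an at least 7.4-fold higher number from compound 1 to compound 4 (0.86 log units; beyond the scatter), and the exchange of methoxy for methyl gives an at least 7.5-fold higher number from compound 3 to compound 4 (0.87 log units; beyond the scatter). The change at this place therefore depends on which group enters, and the chloro substituent also matters with the 4-methylphenyl group held fixed, as chloro in place of hydrogen gives an at least 9.3-fold higher number from compound 2 to compound 4 (0.97 log units; beyond the scatter).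

Among the four compounds shown, a step beyond the scatter appears only where methyl and chloro occur together, and that observation rests on compound 4 alone, with its true size unresolved at the limit. From the compounds shown here alone, whether this holds beyond methyl remains open: ethyl, fluoro or an amine in the same place on the core of compound 4 would test whether the step belongs to methyl specifically or extends to other groups.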